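The compounds below may be only part of what the source reports. "The series", "measured", "known", "first", "only" and "open" are said of these compounds alone.

Measured compounds in the series:
- compound 1, `Cc1nc2c(OCc3ccccc3)nccn2c1N`: 69%
- compound 2, `Cc1nc2c(OCc3ccccc3)cccn2c1C`: 0%
- compound 3, `Cc1nc2c(/C=C\c3ccccc3)cccn2c1C`: 37%

In a functional assay on the whole organism (stomach) for inhibition, with Canis familiaris (Canis lupus familiaris) as the target, at a dose of 4 mg/kg by the oral route (a lower number here means a weaker effect, a higher number a stronger effect of the compound at the dose given), compound 3 stands second highest of the three numbers. Compound 1 sits above it, and that gap is beyond the scatter; compound 2 sits below it, and that gap is also beyond the scatter. For the measured compounds named here, no pair of measured compounds differs in a single place, so no step between measured compounds can be read off, and nothing is known about how the compounds bind.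

Compound 4, `Cc1nc2c(/C=C\c3ccsc3)cccn2c1C`, is unmeasured. Compared with compound 3 the change is thiophen-3-yl in place of phenyl on a double-bonded chain carbon bound to a double-bonded chain carbon. Going by the values given here, the replacement exchanges one aromatic ring for another of similar size on the same double-bonded chain carbon, and the only comparison available is the pair compound 3 and compound 2, which differ in more than one place. In this assay the step of a number 2 percentage points lower from compound 3 to compound 4 (within the scatter) is expected to stay within the scatter, with no firm direction. Compound 4 is estimated to give 35%, within a range from 10% to 60%.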

Compound 4, a percentage reported as inhibition, in the whole organism at one dose (the size of the read-out at that dose, not a potency): 38%
Compound 4: middle estimate off by 3 percentage points, on the low side; the measured number falls inside the stated range.
By their numbers in this assay, from the lowest: compound 2; then compounds 3 and 4 (each within the scatter of the next); then compound 1.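

The series now has its first step in one place: in this assay thiophen-3-yl in place of phenyl on a double-bonded chain carbon bound to a double-bonded chain carbon gives a number 1 percentage points higher from compound 3 to compound 4 (within the scatter). At this single dose, the five-membered aromatic ring with one hetero atom and the six-membered aromatic ring of carbon only therefore cannot be told apart at this position. No supporting measurement is available to explain this outcome.

The compounds shown leave open how a saturated ring such as cyclohexyl, or a phenyl carrying an amine or a carboxylic acid, would read at this place. Also open, as far as these compounds go, is whether the same exchange would read alike on the core of compound 1, or at other doses.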